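The source may report more compounds than this note shows. Statements on the series, on what has been measured and on what is new or still open speak of the compounds shown alone.

Compound 1 `O=C1COc2ccc(-c3nn(-c4ccc(Cl)cc4)cc3-c3ccccc3)cc2N1`: 61.9%
Compound 2 `O=C1COc2ccc(-c3[nH]c(-c4c[nH]c5ncccc45)nc3-c3ccccc3)cc2N1`: 97.7%
Compound 3 `O=C1COc2ccc(-c3[nH]c(-c4ccc(Cl)cc4Cl)nc3-c3ccccc3)cc2N1`: 97.8%

In a functional assay on DLD-1 cells (Homo sapiens) for cytotoxicity, read by colorimetric assay and MTT assay, with a stated time of 3 days, tested at 1 uM (a higher number here means a weaker effect of the compound at the concentration tested, a lower number a stronger effect), compound 1 stands lowest of the three numbers shown; compound 2 lies higher, and compound 3 higher still, both beyond the scatter. Compound 4 `Cc1ccccc1-n1cc(-c2ccccc2)c(-c2ccc3c(c2)NC(=O)CO3)n1` keeps the core of compound 1 and differs in one place: 2-methylphenyl in place of 4-chlorophenyl on an aromatic nitrogen. Among the compounds with values here, the only measured step, a number 0.1 percentage points higher from compound 2 to compound 3 (within the scatter), concerns a different position on a different core and says nothing about a change on the aromatic nitrogen of compound 1. Within the data shown here, no measured step bears on this change. Compound 4 is therefore expected to stay close to compound 1, with a number 6.1 percentage points higher from compound 1 to compound 4 (within the scatter) as the estimated step, most likely within the scatter. The estimate for compound 4 is 68%, within 48% to 92%.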

Compound 4, a percentage reported as activity, at one concentration (the size of the read-out at that concentration, not a potency): 92.2%
Compound 4: the middle estimate sits 24.2 percentage points below what was measured; measured number outside the range, above it.
By their numbers in this assay, from the lowest: compound 1; then compounds 4, 2 and 3 (each within the scatter of the next).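

In this assay, the group on the aromatic nitrogen of the core of compound 1 proves decisive: 2-methylphenyl in place of 4-chlorophenyl gives a number 30.3 percentage points higher from compound 1 to compound 4 (beyond the scatter), a clear loss of effect at the concentration tested. Both groups hold the same number of heavy atoms and one six-membered aromatic ring of carbon only, so those counts do not separate them. Nothing measured here accounts for the step.

Still open, going by these compounds, is whether the step follows the exchange of chlorine for methyl or the different place of the substituent, which 4-methylphenyl or 2-chlorophenyl would separate. On these data alone, how a phenyl ring bearing an amine would behave on this nitrogen also remains unknown.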